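The source may report more compounds than this note shows. Statements on the series, on what has been measured and on what is new or still open speak of the compounds shown alone.

Measured compounds:
Compound 1, `CCC(CC)c1ccc2c(NCCCNCc3cc(F)ccc3OC)ccnc2c1` — in a physicochemical assay for solubility, with a stated time of 18 h, at pH 7.4 (on this read-out lower numbers stand for lower solubility and higher numbers for higher solubility), compound 1 gives 4200 nM.
Compound 2, `CCC(CC)c1ccc2c(NCCCNCc3ccco3)ccnc2c1` — in this assay compound 2 gives 4200 nM.
Compound 3, `CCC(CC)c1ccc2c(NCCCNCc3cccc(OC)c3O)ccnc2c1` — in this assay compound 3 gives 4200 nM.

In this assay compound 2 stands level with compounds 1 and 3 at the digits shown. The three steps among them are no change at the digits printed from compound 1 to compound 2 (within the scatter), no change at the digits printed from compound 2 to compound 3 (within the scatter) and no change at the digits printed from compound 1 to compound 3 (within the scatter), all within the scatter, and each of them exchanges only the group on a saturated chain carbon bound to an amine nitrogen.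

Compound 4, `c1coc(CNCCCNc2ccnc3cc(-c4cccc5ccccc45)ccc23)c1`, differs from compound 2 at a different place: naphthalen-1-yl in place of pentan-3-yl on an aromatic carbon. Going by the values given here, none of the measured steps alters this aromatic carbon, so no measured step bears directly on the change. What the measured steps do show is that exchanging groups at the chain carbon left solubility unchanged across compounds 1, 2 and 3. The change to compound 4 is not of that kind, and the data give no guide to its size. In the absence of a comparable step, a modest move toward lower solubility is expected, with wide uncertainty. For compound 4 the step is expected to be a 2.8-fold lower number from compound 2 to compound 4 (0.45 log units; beyond the scatter). Compound 4 is estimated at 1500 nM, within a range of 300 nM to 5000 nM.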

Compound 4, solubility: 32000 nM
Beside the measured number, compound 4's estimate is 21-fold (1.33 log units) below it; the whole stated range lies below it.
By their numbers in this assay, from the lowest: compounds 1, 2 and 3 (each within the scatter of the next); then compound 4.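

Placing naphthalen-1-yl in place of pentan-3-yl on this aromatic carbon gives a 7.6-fold higher number from compound 2 to compound 4 (0.88 log units; beyond the scatter) in this assay and so marks the first move beyond the scatter among the compounds shown. Going by these compounds alone, compounds 1, 2 and 3 showed only that exchanges at the saturated chain carbon left the printed number where it stood, whereas this step shows that the read-out does respond to a change at the aromatic carbon, at least for this one exchange with the furan-2-yl group held in place. Nothing shown here explains why the number moved in this direction.

As far as these compounds go, a single step cannot separate the loss of pentan-3-yl from the arrival of the two aromatic rings of naphthalen-1-yl, so it remains open whether a phenyl, a pyridin-3-yl or a morpholine at the same aromatic carbon would shift the read-out in the same direction or by a similar amount. From the compounds shown here alone, it also remains open whether the step would hold with 5-fluoro-2-methoxyphenyl or 2-hydroxy-3-methoxyphenyl in place of furan-2-yl on the chain carbon.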